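Ortho-halogen swap on the anilide ring of a phosphodiesterase series

This account rests on a few compounds, and the source may have more. Where it says the series, first, only, none or still open, it means among the compounds named here.

Compound 1 `COc1ccc(C(=O)Nc2ccccc2Cl)cc1OC1CCCC1`, compound 2 `COc1ccc(C(=O)Nc2ccccc2F)cc1OC1CCCC1` and compound 3 `COc1ccc(C(=O)Nc2c(F)c(F)nc(F)c2Cl)cc1OC1CCCC1` share the same acyl part and differ only in the anilide ring. In an assay on isolated protein for inhibition of phosphodiesterase 4A (Sus scrofa) (on this read-out higher numbers stand for weaker inhibition and lower numbers for stronger inhibition), compound 1 gives 190 nM, compound 2 gives 10700 nM and compound 3 gives 100 nM. The change chloro in place of fluoro on an aromatic carbon gave a 56-fold lower number from compound 2 to compound 1 (1.75 log units; beyond the scatter). The difference between the cores of compound 2 and compound 3 is not broken down here. Compound 4 `COc1ccc(C(=O)Nc2c(Cl)c(F)nc(F)c2Cl)cc1OC1CCCC1` is not yet measured; it arises from compound 3 through (chloro in place of fluoro on an aromatic carbon), the same kind of change as before, but here on a six-membered aromatic ring with 1 nitrogen, ortho to a fluoro group, two atoms from the ring nitrogen, meta to a chloro group and para to a fluoro group, rather than on a ring of carbon only. A smaller step is expected for compound 4, a 2.0-fold lower number from compound 3 to compound 4 (0.30 log units; within the scatter), because compound 3 already stands at 100 nM. In this assay compound 4 is estimated at 50 nM, from 15 nM to 200 nM.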

Compound 4, half-maximal inhibitory concentration: 20 nM
Compound 4: middle estimate off by 2.5-fold (0.40 log units), on the high side, and the stated range covers the measured number.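

In this assay chloro in place of fluoro on an aromatic carbon again gives a lower number, a 5.0-fold lower number from compound 3 to compound 4 (0.70 log units; beyond the scatter) and so the direction of the change carries over to the core of compound 3. The size of the step does not carry over: the same change on two cores in this assay, a 56-fold lower number (1.75 log units; beyond the scatter) from compound 2 to compound 1 and a 5.0-fold lower number (0.70 log units; beyond the scatter) from compound 3 to compound 4, 11-fold (1.05 log units) apart, beyond the scatter of two such steps
Two pairs do not show what sets the size of the step, since the cores differ in the ring nitrogen and in the other halogens together, and they do not show how the change would run on a further core.

From the compounds shown here alone, whether a methyl group or a nitrile in place of the entering chloro group would hold the low number remains open. Also open, going by these compounds, is how an amine on this ring would read in this assay on either core.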